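The source may report more compounds than this note shows. Statements on the series, on what has been measured and on what is new or still open speak of the compounds shown alone.

Working notes on an ADME assay on Vero cells (Chlorocebus sabaeus) for cytotoxicity, read by MTT assay, with a stated time of 72 h; a lower number here means that less compound is tolerated, a higher number that more compound is tolerated. For the measured compounds named here, compound 1 (`COc1c(N2CCN(CC(C)=O)C(C)C2)c(F)cc2c(=O)c(C(=O)O)cn(C3CC3)c12`) gives 500 ug/mL, while compound 2 (`CCO/N=C(\C)CCN1CCN(c2c(F)cc3c(=O)c(C(=O)O)cn(C4CC4)c3c2OC)CC1C`) gives 88.4 ug/mL, the lower of the two numbers so far. Going by the values given here, the only measured step is a 5.7-fold lower number from compound 1 to compound 2 (0.75 log units; beyond the scatter), beyond the scatter and modest in size; it replaces a smaller open-chain group with a larger one.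

Compound 3 (`COc1c(N2CCN(CC/C(C)=N/NC(N)=O)C(C)C2)c(F)cc2c(=O)c(C(=O)O)cn(C3CC3)c12`) departs from compound 2 in a single place: ureido in place of ethoxy on a double-bonded nitrogen. Among the compounds with values here, no measured pair isolates this exchange, so the earlier step offers only a rough guide to size and none to direction. Within the data shown here, with only two measured compounds, compound 2 sits at the low end of the numbers, and a move back towards compound 1 is judged more likely than a further fall, though the data cannot confirm this. The expected change is a 2.3-fold higher number from compound 2 to compound 3 (0.35 log units; beyond the scatter), an estimated move smaller than the measured step of a 5.7-fold lower number from compound 1 to compound 2 (0.75 log units; beyond the scatter). For compound 3 the estimated value is 200 ug/mL, with an expected range of 80 ug/mL to 500 ug/mL.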

Compound 3, half-maximal cytotoxic concentration: 31.3 ug/mL
Beside the measured number, compound 3's estimate is 6.4-fold (0.81 log units) above it, and the stated range ends above it.
By their numbers in this assay, from the lowest: compound 3; then compound 2; then compound 1.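

In this assay, ureido in place of ethoxy on a double-bonded nitrogen gives a 2.8-fold lower number from compound 2 to compound 3 (0.45 log units; beyond the scatter), so the number depends on the group at this far end of the side chain and not only on the change from the smaller open-chain group. For the compounds shown here, measured against the smaller group on the saturated chain carbon bound to an amine nitrogen in a ring, the whole exchange gives a 16-fold lower number from compound 1 to compound 3 (1.20 log units; beyond the scatter), the largest step so far, and both larger groups stand lower than the group of compound 1. No measurement on hand bears on what lies behind these falls.

Ureido differs from ethoxy in both its heavy atoms and its hydrogen-bond donors, and this single exchange cannot separate the two. As far as these compounds go, it remains open whether an amine or a longer alkoxy chain on the same double-bonded nitrogen would stay close to compound 2 or fall towards compound 3, and whether the order seen here holds for groups beyond these three.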